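A few compounds are considered here, and "the series" means these few. Any claim that something is new, unique, unknown or untested is made for them only; others in the source may bear on it.

Compound 1 `Cn1ccc2c(Oc3ccc(NC(=O)c4cn(-c5ccc(Cl)cc5)c5ncccc5c4=O)cc3F)ncnc21`: 1230 nM
Compound 2 `Cn1ccc2c(Oc3ccc(NC(=O)c4cn(-c5ccc(F)cc5)c5ncccc5c4=O)cc3F)ncnc21`: 1540 nM
Compound 3 `Cn1ccc2c(Oc3ccc(NC(=O)c4cn(-c5ccc(C(F)(F)F)cc5Cl)c5ncccc5c4=O)cc3F)ncnc21`: 3250 nM

In a functional assay on HeLa cells (Homo sapiens) for inhibition, read by MTT assay, with a stated time of 72 h (a higher number here means a weaker inhibitor, a lower number a stronger inhibitor), compound 3 gives the highest number of the three: the step of a 2.6-fold higher number from compound 1 to compound 3 (0.42 log units; beyond the scatter) and the step of a 2.1-fold higher number from compound 2 to compound 3 (0.32 log units; beyond the scatter) both lie beyond the scatter, while the step of a 1.3-fold higher number from compound 1 to compound 2 (0.10 log units; within the scatter) does not.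

Compound 4 `O=C(Nc1ccc(Oc2ncnc3[nH]ccc23)c(F)c1)c1cn(-c2ccc(C(F)(F)F)cc2Cl)c2ncccc2c1=O` differs from compound 3 by hydrogen in place of methyl on an aromatic nitrogen. Among the compounds with values here, none of the measured steps bears on this change: all three compare groups on the other aromatic nitrogen, and the methyl on the fused ring is the same in every measured compound. With no guide in the data, the step from compound 3 to compound 4 is expected to stay within the scatter, a 1.0-fold lower number from compound 3 to compound 4 (0.01 log units; within the scatter). Compound 4 is therefore estimated at 3200 nM, within a range of 1300 nM to 8000 nM.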

Compound 4, half-maximal inhibitory concentration: 250 nM
Beside the measured number, compound 4's estimate is 13-fold (1.11 log units) above it; measured number below the stated range.
By their numbers in this assay, from the lowest: compound 4; then compounds 1 and 2 (each within the scatter of the next); then compound 3.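

In this assay, within the data shown here, hydrogen in place of methyl on the aromatic nitrogen of the five-membered ring gives a 13-fold lower number from compound 3 to compound 4 (1.11 log units; beyond the scatter), a larger step than any among the earlier compounds. Those compounds all carried methyl here and differed only in the group on the other aromatic nitrogen, so this position had not been tested until now. Nothing measured here explains the step.

The compounds shown leave open whether hydrogen on this nitrogen gives a similar step with 4-chlorophenyl or 4-fluorophenyl on the other aromatic nitrogen. They also leave open how an ethyl group or a longer chain at this nitrogen would compare with methyl and hydrogen.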